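The source may hold more compounds than are shown below. What is called first, only, known or untested is meant among the compounds shown, and "the series" means these compounds.

Measured compounds:
- Compound 1 `CN(C)S(=O)(=O)Nc1cccc2c1CCCC2c1c[nH]cn1`; in an assay on isolated protein (Cricetulus griseus) for binding affinity to Alpha-1B adrenergic receptor (Mesocricetus auratus), read by radioligand binding (on this read-out higher numbers stand for weaker inhibition and lower numbers for stronger inhibition), compound 1 gives < 10000 nM, a limit of the assay.
- Compound 2 `CC(=O)Nc1cccc2c1CCCC2c1c[nH]cn1`; in this assay compound 2 gives < 10000 nM, a limit.
- Compound 3 `O=C(Nc1cccc2c1CCCC2c1c[nH]cn1)C(F)(F)F`; in this assay compound 3 gives < 10000 nM, a limit.

Compound 3 stands only at a limit, as do the other two values, all three sitting at the limit of < 10000 nM in this assay, at which 3 of the 3 values shown sit. The measured steps are a step that the two limits leave unreadable from compound 1 to compound 2, a step that the two limits leave unreadable from compound 1 to compound 3 and a step that the two limits leave unreadable from compound 2 to compound 3; none of them gives a readable size. Compound 4 `Nc1cccc2c1CCCC2c1c[nH]cn1` has not yet been measured; it differs from compound 3 by hydrogen in place of (trifluoromethyl)carbonyl on a nitrogen on an aromatic ring. With no readable step to lean on, a step of the size a step that the limit leaves unreadable from compound 3 to compound 4 is expected, with a real chance that only a limit is reported again. Compound 4 is therefore estimated at 3000 nM, within 300 nM to 10000 nM.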

Compound 4, inhibition constant: 525 nM
Estimate against measurement, compound 4: 5.7-fold (0.76 log units) above, and the stated range covers the measured number.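

No step from compound 1, compound 2 or compound 3 to compound 4 can be given a size, because those three values are limits and not numbers: the limit of < 10000 nM in this assay, at which 3 of the 4 values shown sit.

The compounds shown leave open how compound 4 truly ranks against the other three, and how those three rank among themselves.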